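Trifluoromethyl Step Repeated on a Chlorophenyl Ring

A few compounds are considered here, and "the series" means these few. Any claim that something is new, unique, unknown or untested is made for them only; others in the source may bear on it.

Of the compounds shown here, three sharing one core have been measured in a functional assay for agonist activity at Free fatty acid receptor 1 (Homo sapiens), read by FLIPR, in the presence of a further agent that is not named here; a higher number here means that more compound is needed for the effect, a lower number that less compound is needed. Compound 1 `Cc1cc(C(F)(F)F)cc(Oc2ccc(CC3SC(=O)NC3=O)cc2)n1` gives 218 nM, compound 2 `Cc1cccc(Oc2ccc(CC3SC(=O)NC3=O)cc2)n1` gives 2620 nM, and compound 3 `O=C1NC(=O)C(Cc2ccc(Oc3ccccc3Cl)cc2)S1` gives 1190 nM. The change trifluoromethyl in place of hydrogen on an aromatic carbon made a 12-fold lower number from compound 2 to compound 1 (1.08 log units; beyond the scatter). The cores of compound 2 and compound 3 differ by 2-chlorophenyl in place of 6-methylpyridin-2-yl on an oxygen on an aromatic ring, which gave a 2.2-fold lower number from compound 2 to compound 3 (0.34 log units; beyond the scatter).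

Compound 4 `O=C1NC(=O)C(Cc2ccc(Oc3ccc(C(F)(F)F)cc3Cl)cc2)S1` is not yet measured. It differs from compound 3 by trifluoromethyl in place of hydrogen on an aromatic carbon. This is the same kind of change as that leading to compound 1, not the same: there the ring held 1 nitrogen and the group sat meta to a large group, meta to a methyl group and opposite the ring nitrogen, whereas here the ring is of carbon only and the group sits meta to a chloro group and para to a large group. For the measured compounds named here, compound 4 is expected to show a step of a 4.8-fold lower number from compound 3 to compound 4 (0.68 log units; beyond the scatter), a little smaller than the earlier one because the only guide is a 12-fold lower number from compound 2 to compound 1 (1.08 log units; beyond the scatter) in different surroundings. Compound 4 is estimated at 250 nM, likely between 80 nM and 800 nM.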

Compound 4, half-maximal effective concentration: 78 nM
For compound 4 the middle estimate is 3.2-fold (0.51 log units) above the measured one; the whole stated range lies above it.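

In this assay, trifluoromethyl in place of hydrogen gave a 15-fold lower number from compound 3 to compound 4 (1.18 log units; beyond the scatter), a large step. The earlier case, on a ring holding a nitrogen and a methyl group, gave a step of matching size: the same change on two cores in this assay, a 12-fold lower number (1.08 log units; beyond the scatter) from compound 2 to compound 1 and a 15-fold lower number (1.18 log units; beyond the scatter) from compound 3 to compound 4, 1.3-fold (0.10 log units) apart, within the scatter of two such steps. The change therefore carried over between these two cores with its size intact, but two cores are a small sample, and these results neither explain why the number falls nor predict the step on a third core.

As far as these compounds go, it remains open whether a smaller or different group at the same place, such as a nitrile or a methoxy group, would give a similar step. Also open, from the compounds shown here alone, is whether trifluoromethyl would do the same on a core bearing a carboxylic acid.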